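Aminopyrimidine series: removing the substituent between the ring nitrogens

The compounds below may be only part of what the source reports. "The series", "measured", "known", "first", "only" and "open" are said of these compounds alone.

Measured so far:
compound 1, `Cc1cnc(N)nc1-c1ccccc1`, 34%
compound 2, `Cc1ncc(C)c(-c2ccccc2)n1`, 12%

In a functional assay on the whole organism for inhibition, with Rattus norvegicus as the target, with stated times of 1 h and 3.5 h, at a dose of 100 mg/kg by the oral route (a higher number here means more inhibition at the dose given (going by the name of the read-out), a lower number less inhibition), compound 2 stands lowest of the two numbers; compound 1 lies above it by a number 22 percentage points lower from compound 1 to compound 2 (beyond the scatter). Compound 3, `Cc1cncnc1-c1ccccc1`, differs from compound 2 by hydrogen in place of methyl on an aromatic carbon. For the measured compounds named here, the only measured step, a number 22 percentage points lower from compound 1 to compound 2 (beyond the scatter), changes the group on the same aromatic carbon, so it bears on this change, though it exchanges two different groups. Going by the values given here, no measured step removes a methyl for hydrogen. Compound 3 is therefore expected to stay close to compound 2, with no change at the digits printed from compound 2 to compound 3 (within the scatter) as the estimated step. Compound 3 is estimated at 12%, in the range 0% to 32%.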

Compound 3, a percentage reported as inhibition, in the whole organism at one dose (the size of the read-out at that dose, not a potency): 48%
Beside the measured number, compound 3's estimate is 36 percentage points below it; measured number above the stated range.
By their numbers in this assay, from the lowest: compound 2; then compound 1; then compound 3.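

In this assay, hydrogen in place of methyl on the aromatic carbon between two ring nitrogen atoms gives a number 36 percentage points higher from compound 2 to compound 3 (beyond the scatter), and hydrogen in place of amino there gives a number 14 percentage points higher from compound 1 to compound 3 (beyond the scatter). Neither methyl nor amino is therefore needed at this position for inhibition at this dose, and compound 3, with hydrogen, gives the highest number of the three. No available evidence explains this order. Still open, as far as these compounds go, is how a methoxy group, a chlorine atom or a dimethylamino group would compare at this position.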